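A few compounds are considered here, and "the series" means these few. Any claim that something is new, unique, unknown or untested is made for them only; others in the source may bear on it.

Of the compounds shown here, three have been measured so far in an ADME assay on L6 cells (Rattus norvegicus) for cytotoxicity; a lower number here means a stronger inhibitor, a higher number a weaker inhibitor. Compound 1 (`O=C(NCCCn1cnc([N+](=O)[O-])n1)c1ccc(-c2ccccc2)cc1`) gives 117000 nM, compound 2 (`O=C(Cn1cnc([N+](=O)[O-])n1)N1CCC(Cc2ccccc2)CC1`) gives 144000 nM, and compound 3 (`O=[N+]([O-])c1nccn1CCCNS(=O)(=O)c1ccc(C(F)(F)F)cc1`) gives 176000 nM. The gaps from compound 3 to the other two lie within the usual scatter of repeated measurements, so it stands level with them.

Compound 4 (`O=[N+]([O-])c1ncn(CCCNS(=O)(=O)c2ccc(C(F)(F)F)cc2)n1`) has 3-nitro-1H-1,2,4-triazol-1-yl in place of 2-nitro-1H-imidazol-1-yl on a saturated chain carbon, three bonds along the chain from a sulfonamide nitrogen.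

For the measured compounds named here, no measured pair differs in this one place alone, so the evidence is indirect. Compound 1 at 117000 nM and compound 2 at 144000 nM already carry the 3-nitro-1H-1,2,4-triazol-1-yl group, yet the rest of their structures differs from compound 3. Even so, their values sit within the scatter of compound 3 at 176000 nM. No step beyond the scatter is therefore expected in this assay. The estimated change is a 1.2-fold lower number from compound 3 to compound 4 (0.07 log units; within the scatter). Compound 4 is expected at 150000 nM, with an estimated range from 70000 nM to 300000 nM.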

Compound 4, half-maximal inhibitory concentration: 235000 nM
For compound 4 the middle estimate is 1.6-fold (0.19 log units) below the measured one, and the stated range covers the measured number.
By their numbers in this assay, from the lowest: compounds 1, 2, 3 and 4 (each within the scatter of the next).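

For the compounds shown here, this is the first pair that isolates the nitro-bearing ring, since the earlier compounds differ from one another in more than one place. In this assay the result is a 1.3-fold higher number from compound 3 to compound 4 (0.13 log units; within the scatter) and so, with the rest of the molecule held fixed, 3-nitro-1H-1,2,4-triazol-1-yl and 2-nitro-1H-imidazol-1-yl on this saturated chain carbon cannot be told apart. No measured property is available to bear on this result.

This single pair cannot show whether the two rings would stay level on a different scaffold, such as the amide of compound 1. It also leaves open whether a longer chain in place of the present one, or an amine or a carboxylic acid in place of the trifluoromethyl group, would move the number beyond the scatter.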